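Swapping Methyl for Fluoro on the Phenyl Ring

The compounds below may be only part of what the source reports. "The series", "measured", "known", "first", "only" and "open" are said of these compounds alone.

Measured so far in a functional assay on HEK293 cells for agonist activity at D(4) dopamine receptor (Homo sapiens), read by FLIPR; a higher number here means that more compound is needed for the effect, a lower number that less compound is needed:
compound 1 `Cc1cccc(NC(=O)CN2CCC(c3ccccc3)CC2)c1` gives 170 nM
compound 2 `Cc1cccc(NC(=O)CN2CCC(c3ccccc3C)CC2)c1` gives 340 nM

Compound 2 has the higher of the two numbers; its nearest neighbour is compound 1, and the step of a 2.0-fold higher number from compound 1 to compound 2 (0.30 log units; within the scatter) lies within the scatter. Compound 3 `Cc1cccc(NC(=O)CN2CCC(c3ccccc3F)CC2)c1` differs from compound 2 by fluoro in place of methyl on an aromatic carbon. Among the compounds with values here, the only measured step, a 2.0-fold higher number from compound 1 to compound 2 (0.30 log units; within the scatter), shows that exchanging hydrogen for methyl at this carbon barely moves the number. Putting fluoro in place of methyl at the same carbon is therefore expected to give no step beyond the scatter, a 1.4-fold lower number from compound 2 to compound 3 (0.13 log units; within the scatter). For compound 3 the expected value in this assay is 250 nM, within a range from 100 nM to 600 nM.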

Compound 3, half-maximal effective concentration: 1 nM
Compound 3: the middle estimate sits 250-fold (2.40 log units) above what was measured; the whole stated range lies above it.
By their numbers in this assay, from the lowest: compound 3; then compounds 1 and 2 (each within the scatter of the next).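

Fluoro in place of methyl gives a 340-fold lower number from compound 2 to compound 3 (2.53 log units; beyond the scatter) and fluoro in place of hydrogen gives a 170-fold lower number from compound 1 to compound 3 (2.23 log units; beyond the scatter) at this same carbon. The number at this carbon can therefore move far beyond the scatter, which the hydrogen-to-methyl step did not reveal, and the change depends on which single atom is attached. Nothing available explains this large drop. As far as these compounds go, whether the drop is particular to fluoro stays open, and chloro or methoxy at this carbon would test that. Also open, from the compounds shown here alone, is whether fluoro on another carbon of this ring would produce a similar step.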